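The compounds below may be only part of what the source reports. "The series", "measured", "known", "first", "only" and "open" are said of these compounds alone.

Of the compounds shown here, three have been measured in a functional assay on MCF7 cells (Homo sapiens) for inhibition; on this read-out higher numbers stand for weaker inhibition of growth and lower numbers for stronger inhibition of growth. Compound 1 `COc1cc(/C=C/C(=O)c2cccc(-n3cc(-c4ccccc4)[nH]c3=O)c2)cc(OC)c1OC` gives 310 nM. Compound 2 `COc1cc(/C=C/C(=O)c2cccc(-n3cc(-c4ccccc4)[nH]c3=O)c2)ccc1O` gives 1550 nM, the second highest number of the three; its nearest neighbour is compound 3 `COc1ccc(-c2cn(-c3cccc(C(=O)/C=C/c4ccc(O)c(OC)c4)c3)c(=O)[nH]2)cc1`, which gives 3180 nM, and the step from compound 2 to compound 3 is a 2.1-fold higher number from compound 2 to compound 3 (0.31 log units; beyond the scatter), a methoxy in place of hydrogen on an aromatic carbon of the phenyl ring of the shared core. Compound 1 stands furthest from compound 2, with a lower number.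

Compound 4 `O=C(/C=C/c1cccc(O)c1)c1cccc(-n2cc(-c3ccccc3)[nH]c2=O)c1` has not yet been measured. It differs from compound 2 in one place: 3-hydroxyphenyl in place of 4-hydroxy-3-methoxyphenyl on a double-bonded chain carbon bound to a double-bonded chain carbon. Going by the values given here, no measured step touches this part of the molecule, so the measured steps bear on it only loosely. Among the compounds with values here, the one step available, from compound 2 to compound 3, sits on the other aryl ring, and compound 1, which carries more methoxy groups on the chain-bound ring than compound 2, gives the lowest number. With fewer oxygen groups on the chain-bound ring, compound 4 is expected to give a somewhat higher number, the step from compound 2 to compound 4 being estimated at a 1.9-fold higher number from compound 2 to compound 4 (0.29 log units; within the scatter). Compound 4 is therefore estimated at 3000 nM, within a range from 1000 nM to 9000 nM.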

Compound 4, concentration for 50% growth inhibition: 2470 nM
Compound 4: middle estimate off by 1.2-fold (0.08 log units), on the high side; the range from low to high includes it.
By their numbers in this assay, from the lowest: compound 1; then compounds 2, 4 and 3 (each within the scatter of the next, the first and the last beyond it).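

In this assay, going by these compounds alone, the exchange of 4-hydroxy-3-methoxyphenyl for 3-hydroxyphenyl on a double-bonded chain carbon bound to a double-bonded chain carbon gives a 1.6-fold higher number from compound 2 to compound 4 (0.20 log units; within the scatter) and is the first step measured at this position, the earlier step having sat on the other aryl ring. At this position, the ring can therefore lose its methoxy group and take the 3-hydroxyphenyl form without a difference that can be told from the scatter. Nothing available accounts for this result.

The two parts of the exchange stay unseparated, since the compounds shown do not tell what the loss of the methoxy group and the different placing of the hydroxy group each contribute. As far as these compounds go, it also remains open how an amine or a carboxylic acid in place of the hydroxy group on this ring would read in this assay, and whether the ring needs a hydroxy group at all.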